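The compounds below may be only part of what the source reports. "The series", "measured", "known", "first", "only" and "open" are said of these compounds alone.

Working notes on the series. Three analogues have been measured in a functional assay on HCT-116 cells (Homo sapiens) for antiproliferative activity, read by CCK-8 assay, with a stated time of 72 h; a lower number here means a stronger inhibitor, a higher number a weaker inhibitor. Compound 1 `Cc1ccc(Nc2nc(Cl)nc3c2ncn3Cc2ccc(C(=O)Nc3ccccc3N)cc2)cc1` gives 580 nM. Compound 2 `Nc1ccccc1NC(=O)c1ccc(Cn2cnc3c(Nc4ccccc4)nc(Cl)nc32)cc1` gives 1070 nM, and compound 3 `Nc1ccccc1NC(=O)c1ccc(Cn2cnc3c(NCc4ccccc4)nc(Cl)nc32)cc1` gives 1060 nM. Compound 3 stands second highest of the three numbers, with a 1.0-fold lower number from compound 2 to compound 3 (0.00 log units; within the scatter) and a 1.8-fold higher number from compound 1 to compound 3 (0.26 log units; within the scatter); the remaining step is a 1.8-fold higher number from compound 1 to compound 2 (0.27 log units; within the scatter). Compound 4 `CC1CCN(c2nc(Cl)nc3c2ncn3Cc2ccc(C(=O)Nc3ccccc3N)cc2)CC1` differs from compound 3 by 4-methylpiperidin-1-yl in place of benzylamino on an aromatic carbon. The steps bearing on this place, from compound 1 and compound 2 to compound 3, all stay within the scatter, though none of them removes the hydrogen-bond donor or brings in a non-aromatic ring. No step beyond the scatter is therefore expected in this assay. Compound 4 is estimated at 1000 nM, range 400 nM to 2500 nM, meaning an expected 1.1-fold lower number from compound 3 to compound 4 (0.03 log units; within the scatter).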

Compound 4, half-maximal inhibitory concentration: 950 nM
Compound 4: the middle estimate sits 1.1-fold (0.02 log units) above what was measured; the measured number falls inside the stated range.
By their numbers in this assay, from the lowest: compounds 1, 4, 3 and 2 (each within the scatter of the next).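

For the compounds shown here, with 4-methylpiperidin-1-yl, the position loses the hydrogen-bond donor and the aromatic ring and gains a non-aromatic ring, which the earlier compounds did not test. In this assay the number still stays within the scatter (a 1.1-fold lower number from compound 3 to compound 4 (0.05 log units; within the scatter)) and (a 1.1-fold lower number from compound 2 to compound 4 (0.05 log units; within the scatter)) and (a 1.6-fold higher number from compound 1 to compound 4 (0.21 log units; within the scatter)), so neither feature is required at this place in these compounds. No measurement offers an explanation for this result. Open, as far as these compounds go, is whether morpholin-4-yl, diethylamino or a group carrying a carboxylic acid at this place would stay within the same scatter.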